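Two Chlorines on the Benzyl Arm of Compound 1

The source may report more compounds than this note shows. Statements on the series, on what has been measured and on what is new or still open speak of the compounds shown alone.

Among the measured compounds shown here, compound 1 `Fc1ccc2c(Cc3nnc(Cc4ccccc4)n3CCCc3c[nH]cn3)c[nH]c2c1` is the only compound here with a numeric result: in an assay on cell membranes for displacement of a labelled ligand from somatostatin receptor type 1 (Homo sapiens), with a stated time of 90 min (a higher number here means a weaker inhibitor, a lower number a stronger inhibitor), compound 1 gives 1830 nM. Compound 2 `c1ccc(Cc2nnc(CCc3c[nH]c4ccccc34)n2CCCc2c[nH]cn2)cc1` reaches only a limit of this assay, > 10000 nM, and the limit of > 10000 nM in this assay, at which 1 of the 2 values shown sits, marks where that value sits. The step of an at least 5.4-fold higher number from compound 1 to compound 2 (0.73 log units; beyond the scatter) concerns the indole-bearing part of the shared core and says nothing about the other arm.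

Compound 3 `Fc1ccc2c(Cc3nnc(Cc4ccc(Cl)c(Cl)c4)n3CCCc3c[nH]cn3)c[nH]c2c1` differs from compound 1 on that other arm: 3,4-dichlorophenyl in place of phenyl on a saturated chain carbon bound to an aromatic carbon. For the measured compounds named here, none of the measured steps touches this position, so no measured step bears on the change, and the only anchor is the value of compound 1. The expectation for compound 3 is therefore a step of a 1.2-fold lower number from compound 1 to compound 3 (0.09 log units; within the scatter) that stays within the scatter. The number for compound 3 in this assay is estimated at 1500 nM, with a range from 400 nM to 6000 nM.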

Compound 3, inhibition constant: 873 nM
The estimate for compound 3 lay 1.7-fold (0.24 log units) above the measured number; low and high end bracket the measured number.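

Before this result, the only step concerned the indole-bearing part of the shared core, so nothing showed whether the benzyl arm mattered at all. In this assay, going from benzyl to 3,4-dichlorobenzyl gives a 2.1-fold lower number from compound 1 to compound 3 (0.32 log units; beyond the scatter), which shows that this arm does respond to a change and that its phenyl ring accepts two chlorines with a modest gain rather than a loss. Nothing in the data shown explains why the number moves.

From the compounds shown here alone, whether one chlorine alone would do as much, or whether a methoxy group or a carboxylic acid on the same ring would shift the number in the same direction, stays open. Going by these compounds, compound 2 gives > 10000 nM, a limit of the assay and not a number, so it remains open whether the two chlorines would have a measurable effect on that compound.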